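The source may hold more compounds than are shown below. What is called first, only, known or untested is meant among the compounds shown, and "the series" means these compounds.

Working notes on the series. Compound 1 `O=C1O[C@@H](CO)CN1c1ccc(-n2cc(-c3ccccn3)cn2)c(F)c1`, compound 2 `O=C1O[C@@H](CN2CCC(O)CC2)CN1c1ccc(-n2cc(-c3ccccn3)cn2)c(F)c1` and compound 3 `O=C1CNC(=O)N1C[C@H]1CN(c2ccc(-n3cc(-c4ccccn4)cn3)c(F)c2)C(=O)O1` share one core and differ only in the group on a saturated chain carbon bound to a saturated ring carbon. In an ADME assay on HEK293-A cells (Homo sapiens) for cytotoxicity, read by MTT assay, with a stated time of 48 h (a lower number here means a stronger inhibitor, a higher number a weaker inhibitor), compound 1 gives > 400 ug/mL, which is a limit of the assay and not a number. Compound 2 gives > 400 ug/mL in this assay, again a limit. Compound 3 gives > 400 ug/mL in this assay, also a limit. The three steps, a step that the two limits leave unreadable from compound 1 to compound 2, a step that the two limits leave unreadable from compound 1 to compound 3 and a step that the two limits leave unreadable from compound 2 to compound 3, are therefore unreadable in size, since every value sits at the limit of > 400 ug/mL in this assay, at which 3 of the 3 values shown sit. Compound 3 thus stands at that limit with no number to place it against the other two.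

Compound 4 `CCC(=O)NC[C@H]1CN(c2ccc(-n3cc(-c4ccccn4)cn3)c(F)c2)C(=O)O1` is the next member, and the change is propanoylamino in place of 2,5-dioxoimidazolidin-1-yl on a saturated chain carbon bound to a saturated ring carbon. The measured steps that bear on this change are the three just named, and none of them yields a readable size; the only common ground is that each of the three groups tried so far leaves the value at the limit. On that basis compound 4 is expected to give 500 ug/mL in this assay, within an estimated range from 250 ug/mL to 1000 ug/mL. The step that the limit leaves unreadable from compound 3 to compound 4 is estimated to lie within the scatter.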

Compound 4, half-maximal inhibitory concentration: 389 ug/mL
Beside the measured number, compound 4's estimate is 1.3-fold (0.11 log units) above it; measured number inside the range.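

Propanoylamino on a saturated chain carbon bound to a saturated ring carbon gives the only number in the series so far in this assay, which shows that a group at this place can yield a value inside the range of the assay and not only at its limit: the limit of > 400 ug/mL in this assay, at which 3 of the 4 values shown sit.

Against the three earlier groups the change can be read only as floors, namely an at least 1.0-fold lower number from compound 3 to compound 4 (0.01 log units; that floor lies within the scatter) and an at least 1.0-fold lower number from compound 2 to compound 4 (0.01 log units; that floor lies within the scatter) and an at least 1.0-fold lower number from compound 1 to compound 4 (0.01 log units; that floor lies within the scatter). Each floor lies within the scatter, so replacing hydroxy, 4-hydroxypiperidin-1-yl or 2,5-dioxoimidazolidin-1-yl with propanoylamino is not shown to shift the value by more than repeated measurements would.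

On these data alone, how far the true values of compound 1, compound 2 and compound 3 lie from their shared limit remains open, and with it the real size of all three steps. The compounds shown also leave open what a primary amine, a carboxylic acid or an acyl chain longer than propanoyl would give at this place, and whether any such group would bring the value clearly lower.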